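The source may hold more compounds than are shown below. What is called first, only, known or untested is meant among the compounds shown, and "the series" means these compounds.

Values in a functional assay on Jurkat cells (Homo sapiens) for antiproliferative activity, read by MTT assay, with a stated time of 72 h (on this read-out lower numbers stand for stronger inhibition and higher numbers for weaker inhibition), so far
- compound 1 `COc1cc(C(=O)c2sc3ccccc3c2-c2ccccc2)cc(OC)c1OC` at 1500 nM
- compound 2 `COc1cc(C(=O)c2sc3ccccc3c2-c2ccc(Cl)cc2)cc(OC)c1OC` at 3700 nM
- compound 3 `COc1cc(C(=O)c2sc3ccccc3c2-c2ccc(C)cc2)cc(OC)c1OC` at 3300 nM

Compound 1 has the lowest number of the three, and compound 2 and compound 3 both lie beyond the scatter from it. Compound 4 `COc1ccc(-c2c(C(=O)c3cc(OC)c(OC)c(OC)c3)sc3ccccc23)cc1` differs from compound 1 by methoxy in place of hydrogen on an aromatic carbon as methoxy in place of hydrogen on an aromatic carbon, para to a large group (phenyl to 4-methoxyphenyl). The closest evidence is a 2.5-fold higher number from compound 1 to compound 2 (0.39 log units; beyond the scatter) and a 2.2-fold higher number from compound 1 to compound 3 (0.34 log units; beyond the scatter) as two modest steps, while a 1.1-fold lower number from compound 2 to compound 3 (0.05 log units; within the scatter) stays within the scatter. Among the compounds with values here, both replacements of hydrogen raised the number, but methoxy itself has no measurement yet, so the range stays wide. In this assay a modest rise is expected, with a 2.1-fold higher number from compound 1 to compound 4 (0.33 log units; beyond the scatter) as the estimated step. The estimate for compound 4 is 3200 nM with an expected range of 800 nM to 7000 nM for now.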

Compound 4, half-maximal inhibitory concentration: 1600 nM
For compound 4 the middle estimate is 2.0-fold (0.30 log units) above the measured one; the measured number falls inside the stated range.
By their numbers in this assay, from the lowest: compounds 1 and 4 (each within the scatter of the next); then compounds 3 and 2 (each within the scatter of the next).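

In this assay the place para to a large group accepts methoxy: a 1.1-fold higher number from compound 1 to compound 4 (0.03 log units; within the scatter) stays within the scatter, so adding a group here does not by itself raise the number. Methoxy parts from the other two replacements, with a 2.1-fold lower number from compound 3 to compound 4 (0.31 log units; beyond the scatter) and a 2.3-fold lower number from compound 2 to compound 4 (0.36 log units; beyond the scatter) as modest steps beyond the scatter. No measurement at hand bears on why methoxy differs from methyl and chloro.

Open, going by these compounds, is whether a hydroxyl, an amine or a longer alkoxy chain at this place would track methoxy or instead follow methyl and chloro.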